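The compounds below may be only part of what the source reports. "The series", "measured", "known", "first", "only" and "open" are said of these compounds alone.

Compound 1 `O=C1c2cccc3c2c(cc2c4ccccc4oc32)C(=O)N1CN1CCNCC1` gives > 100000 nM in a functional assay on A549 cells (Homo sapiens) for cytotoxicity, read by sulforhodamine B assay; on this read-out lower numbers stand for stronger inhibition and higher numbers for weaker inhibition.
Compound 2 `CN(C)CCCN1C(=O)c2cccc3c2c(cc2c4ccccc4sc32)C1=O` gives 250 nM in this assay.

The value for compound 1 is a limit of the assay, not a number: it stands at the limit of > 100000 nM in this assay, at which 1 of the 2 values shown sits. Compound 3 `CN(C)CCCN1C(=O)c2cccc3c2c(cc2c4ccccc4oc32)C1=O` differs from compound 1 by 2-(dimethylamino)ethyl in place of piperazin-1-yl on a saturated chain carbon bound to an amide-type nitrogen in a ring; the entering 3-(dimethylamino)propyl is the same chain that compound 2 carries. The step of an at least 160-fold lower number from compound 1 to compound 3 (2.22 log units; beyond the scatter) is expected to be a large move toward stronger inhibition, though its true size cannot be known while the starting point is only a limit. Because compound 2 gives 250 nM, compound 3 is estimated at about 600 nM, expected to fall between 120 nM and 3000 nM.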

Compound 3, half-maximal inhibitory concentration: 740 nM
Estimate against measurement, compound 3: 1.2-fold (0.09 log units) below; measured number inside the range.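

In this assay, the step from (piperazin-1-yl)methyl to 3-(dimethylamino)propyl on the amide-type nitrogen in a ring gives an at least 130-fold lower number from compound 1 to compound 3 (2.13 log units; beyond the scatter). On this shared core, then, the group at this position can move the read-out by a large amount. Compound 1 stands at a limit of the assay and not at a number, so the true size of the step stays unknown: the limit of > 100000 nM in this assay, at which 1 of the 3 values shown sits.

The step changes the ring and the chain length together, and the compounds shown do not separate the two. A 3-(piperazin-1-yl)propyl group, or a longer chain ending in dimethylamino, would help to tell them apart.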